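Opening Notes on Amide Chain Extension in a Cytotoxicity Series

The compounds below may be only part of what the source reports. "The series", "measured", "known", "first", "only" and "open" are said of these compounds alone.

Compound 1, `C=CC1=C(C(=O)NCCC)C(c2ccc(F)cc2)OC1`: > 100000 nM
Compound 2, `C=CC1=C(C(=O)NCc2ccccc2)C(c2ccc(OC)cc2)OC1`: > 100000 nM
Compound 3, `C=CC1=C(C(=O)NCC(C)C)C(c2ccc(Cl)c(Cl)c2)OC1`: > 100000 nM

In a functional assay on QGY7701 cells (Homo sapiens) for cytotoxicity, read by MTT assay, with a stated time of 24 h (on this read-out higher numbers stand for weaker inhibition and lower numbers for stronger inhibition), compound 1 gives > 100000 nM, which is a limit of the assay rather than a number. Compound 2 likewise gives > 100000 nM, also a limit. Compound 3 gives > 100000 nM, again a limit. The picture so far is the limit of > 100000 nM in this assay, at which 3 of the 3 values shown sit; compound 1 therefore stands with the others, without a number of its own. Among the measured compounds shown here, no step between measured compounds can be drawn.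

Compound 4, `C=CC1=C(C(=O)NCCCCC)C(c2ccc(F)cc2)OC1`, differs from compound 1 by ethyl in place of hydrogen on a saturated chain carbon, three bonds along the chain from an amide-type nitrogen. With every measured value at the limit, the step in this assay is expected to be none beyond the scatter, and compound 4 is expected to sit at the limit as well. The estimate for compound 4 is 150000 nM, with a range from 50000 nM to 500000 nM. That estimate means an expected step that the limit leaves unreadable from compound 1 to compound 4.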

Compound 4, half-maximal inhibitory concentration: > 100000 nM
Compound 4 was reported as a limit; the forecaster's own chance of this, stated with the estimate: 85%; the middle value does not contradict the limit.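

No step can be read from compound 1 to compound 4, as both values are limits rather than numbers: the limit of > 100000 nM in this assay, at which 4 of the 4 values shown sit.

In this assay the compounds shown leave open which change to the shared core would give a readable number.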